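Compound 2 and Its Double-Bond Partner, Compound 3

The source may hold more compounds than are shown below. What is called first, only, known or untested is meant among the compounds shown, and "the series" means these compounds.

Measured so far in an ADME assay on NIH3T3 cells (Mus musculus) for cytotoxicity, read by WST assay, with a stated time of 72 h; on this read-out lower numbers stand for higher toxicity in this test and higher numbers for lower toxicity in this test:
- Compound 1 `CCCCCCCC/C=C\c1c(C)nc(C)c(/C=C\CCCCCCCC)c1C`: "not determined" (no result reported)
- Compound 2 `CCCCCCCC/C=C/c1c(C)c(/C=C/CCCCCCCC)c2[n+](c1C)CCC2`: 4.4 uM

Among the measured compounds shown here, compound 2 holds the only number in this small set, so it cannot yet be ranked against anything, and compound 1 offers no result for comparison. The next compound to be tested is compound 3 `CCCCCCCC/C=C\c1c(C)c(/C=C/CCCCCCCC)c2[n+](c1C)CCC2`. The change is small: the two compounds have the same atoms and bonds and differ only in configuration as drawn: 1 of 2 stereo elements differ; a double bond is drawn E in compound 2 and Z in compound 3. The two compounds have the same atoms and bonds and differ only in configuration as drawn, with a double bond drawn E in compound 2 and Z in compound 3. For the measured compounds named here, no measured pair here shows what such a switch does in this assay, so no direction is favoured. The expected size of a 1.0-fold higher number from compound 2 to compound 3 (0.01 log units; within the scatter) lies within the usual scatter of repeated measurements. This expectation rests only on compound 2 at 4.4 uM. The estimated value for compound 3 is 4.5 uM, with an expected range from 2 uM to 10 uM.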

Compound 3, half-maximal toxic concentration: 3.3 uM
Estimate against measurement, compound 3: 1.4-fold (0.13 log units) above; the range from low to high includes it.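

In this assay, switching one double bond from E to Z gives a 1.3-fold lower number from compound 2 to compound 3 (0.12 log units; within the scatter), so the two compounds cannot be told apart in this test. Among the compounds shown here, this is the first measured pair in the set, and it shows that the drawn geometry of this one double bond does not move the number beyond the usual scatter. For the compounds shown here, the comparison is a clean one, because only one feature separates the pair: the fact that compounds 2 and 3 differ only in the configuration as drawn.

The compounds shown leave open what happens when the other double bond, drawn E in both compounds, is also drawn Z. They also leave open whether a shorter chain, or a chain carrying a carboxylic acid, in place of these long chains would give a different number.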